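This account rests on a few compounds, and the source may have more. Where it says the series, first, only, none or still open, it means among the compounds named here.

Measured compounds:
compound 1 `O=C(CCCCCCc1ccccc1)c1ncc(-c2ccc(F)cc2)o1`, 62 nM
compound 2 `COc1ncc(-c2cnc(C(=O)CCCCCCc3ccccc3)o2)c(OC)n1`, 26 nM

Both compounds were tested in an assay (Rattus norvegicus) for inhibition of Fatty-acid amide hydrolase 1 (Homo sapiens); a higher number here means a weaker inhibitor, a lower number a stronger inhibitor. Compound 1 stands at the higher of the two numbers: compound 2, the nearest neighbour, gives 26 nM, a gap that lies beyond the usual scatter, so compound 2 is the stronger inhibitor of the two. Among the measured compounds shown here, no pair among the measured compounds differs in a single place, so no measured step can be used directly to judge a new change.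

Compound 3 `CC(=O)c1cnc(C(=O)CCCCCCc2ccccc2)o1` has not yet been measured. It differs from compound 1 as follows: acetyl in place of 4-fluorophenyl on an aromatic carbon. The large group on the shared core, the seven-carbon chain ending in a phenyl ring, is kept unchanged, and only the substituent on the five-membered ring is swapped.

For the measured compounds named here, with no measured step to lean on, the expectation for compound 3 can rest only on its closeness to compound 1 and on the modest difference seen between compound 1 and compound 2. A small step is expected, a 1.4-fold lower number from compound 1 to compound 3 (0.14 log units; within the scatter), likely not beyond the scatter. Compound 3 is therefore estimated at 45 nM, with a range from 12 nM to 160 nM.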

Compound 3, inhibition constant: 2 nM
For compound 3 the middle estimate is 23-fold (1.35 log units) above the measured one; measured number outside the range, below it.
By their numbers in this assay, from the lowest: compound 3; then compound 2; then compound 1.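

In this assay, putting acetyl in place of 4-fluorophenyl on the aromatic carbon next to the ring oxygen gives a 31-fold lower number from compound 1 to compound 3 (1.49 log units; beyond the scatter). Among the compounds shown here, this shows that the substituent at this position has a large effect on the number, which the earlier compounds could not show, as they did not differ in one place only. It also shows that no ring is needed here for a low number: the entering group has no ring and 3 heavy atoms against 7, and it carries 1 hydrogen-bond acceptor where 4-fluorophenyl carries 0, but the data offer no explanation for the size of this step.

A single step cannot tell whether the loss of the aromatic ring, the smaller size or the carbonyl of the acetyl accounts for the drop. Open too, on these data alone, is how a methyl ester, a nitrile or a carboxylic acid on the same carbon would compare with acetyl, and whether the step would stay this large with a longer chain in place of the large group.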